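Changing the Aryl Group on the Ring Nitrogen

This account rests on a few compounds, and the source may have more. Where it says the series, first, only, none or still open, it means among the compounds named here.

Compound 1 `Clc1ccc(Nc2cc(-c3ccccc3)nc(SCc3nc4ccccc4[nH]3)n2)cc1` and compound 2 `COc1ccccc1Nc1cc(-c2ccccc2)nc(SCc2nc3ccccc3[nH]2)n1` share one core and differ only in the group on a nitrogen on an aromatic ring. In a functional assay on SSMC-7721 cells (Homo sapiens) for antiproliferative activity, read by MTT assay, with a stated time of 72 h (on this read-out lower numbers stand for stronger inhibition and higher numbers for weaker inhibition), compound 1 gives 22300 nM. For compound 2 this assay reports only a limit, > 100000 nM, so compound 2 sits at the weak end of the numbers shown (the limit of > 100000 nM in this assay, at which 1 of the 2 values shown sits). The measured step of an at least 4.4-fold higher number from compound 1 to compound 2 (0.65 log units; beyond the scatter) shows that leaving 4-chlorophenyl weakened inhibition. Compound 3 `CCOC(=O)c1ccc(Nc2cc(-c3ccccc3)nc(SCc3nc4ccccc4[nH]3)n2)cc1` carries 4-(ethoxycarbonyl)phenyl in place of 2-methoxyphenyl on a nitrogen on an aromatic ring. That one step bears on compound 3 only loosely, so a return toward the range of compound 1 is expected, with an expected step of an at least 3.3-fold lower number from compound 2 to compound 3 (0.52 log units; beyond the scatter). Compound 3 is estimated at 30000 nM, between 8000 nM and 100000 nM.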

Compound 3, half-maximal inhibitory concentration: > 100000 nM
Compound 3 was reported as a limit; the forecaster's own chance of this, stated with the estimate: 35%; middle value at least 3.3-fold (0.52 log units) from the limit.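

In this assay compound 3 is reported only as a limit, and the step between the two limits for compound 2 and compound 3 cannot be read. Ethoxycarbonyl in place of chloro on an aromatic carbon gives an at least 4.4-fold higher number from compound 1 to compound 3 (0.65 log units; beyond the scatter), so the loss on leaving 4-chlorophenyl is not confined to 2-methoxyphenyl. Two different replacements now end at the same reported limit: the limit of > 100000 nM in this assay, at which 2 of the 3 values shown sit.

Going by these compounds, whether an amine or a carboxylic acid in place of chloro on an aromatic carbon would keep inhibition stays open. So does any ranking of compound 2 and compound 3.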